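Swapping a pyridine for a thiophene on a shared core

The source may report more compounds than this note shows. Statements on the series, on what has been measured and on what is new or still open speak of the compounds shown alone.

Compound 1 `Oc1cccc(-c2cc(-c3cccc(Cl)c3)nc(-c3ccccn3)c2)c1` has no reported result in a functional assay on T47D cells (Homo sapiens) for cytotoxicity, read by CCK-8 assay and cell counting, with a stated time of 2 days (a lower number here means a stronger inhibitor, a higher number a weaker inhibitor), where its entry reads "not determined" (no result reported), so it stands on no number there. Its close relative compound 2 `Oc1cccc(-c2cc(-c3ccc(Cl)cc3)nc(-c3ccccn3)c2)c1` gives 13900 nM in this assay, a weak value. Compound 3 `Oc1cccc(-c2cc(-c3ccsc3)nc(-c3cccc(Cl)c3)c2)c1` differs from compound 1 by thiophen-3-yl in place of pyridin-2-yl on an aromatic carbon. With no number for compound 1, the step to compound 3 cannot be sized; going by compound 2 at 13900 nM, a similarly weak result is expected, with any shift from compound 1 likely no larger than the scatter in this assay. Compound 3 is estimated at 15000 nM, in the range 4000 nM to 50000 nM.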

Compound 3, half-maximal inhibitory concentration: 3540 nM
Compound 3: middle estimate off by 4.2-fold (0.63 log units), on the high side, outside the stated range (below it).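

Within the data shown here, compound 1 has no number to set against compound 3 in this assay so no step between them can be read. As far as these compounds go, what replacing pyridin-2-yl with thiophen-3-yl does to the value stays open. Nothing available explains the result.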